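The compounds below may be only part of what the source reports. "The series", "measured", "known", "first", "only" and "open" are said of these compounds alone.

Working notes on the series, read in an ADME assay on MRC5 cells (Homo sapiens) for cytotoxicity, read by fluorescence and resazurin assay, with a stated time of 3 days; on this read-out lower numbers stand for stronger inhibition and higher numbers for weaker inhibition. Compound 1 (`Cc1cccc(Oc2cccc(CN3CCC(n4cc(C)c(=O)[nH]c4=O)CC3)c2)c1`) gives > 64000 nM, which is a limit and not a number. Compound 2 (`Cc1cn(C2CCN(Cc3cncc(Oc4cc(Cl)cc(Cl)c4)c3)CC2)c(=O)[nH]c1=O`) gives > 64000 nM, which is also a limit. Among the compounds with values here, compound 1 therefore stands at the limit of > 64000 nM in this assay, at which 2 of the 2 values shown sit, so no exact value is available and no step between measured compounds can be read.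

Compound 3 (`COc1cccc(Oc2cccc(CN3CCC(n4cc(C)c(=O)[nH]c4=O)CC3)c2)c1`) differs from compound 1 in one place: methoxy in place of methyl on an aromatic carbon. This is methoxy in place of methyl on an aromatic carbon, meta to a large group, and the rest of the core of compound 1 is unchanged.

With compound 1 at the limit of > 64000 nM in this assay, at which 2 of the 2 values shown sit, no step beyond the scatter is expected in this assay, and no direction is favoured. The expected step is a number no higher from compound 1 to compound 3 (the limit leaves the size open). For compound 3 the estimated value is 64000 nM, with an expected range from 32000 nM to 64000 nM.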

Compound 3, half-maximal inhibitory concentration: 25300 nM
Compound 3: middle estimate off by 2.5-fold (0.40 log units), on the high side; the measured number lies below the stated range.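

In this assay, within the data shown here, methoxy in place of methyl on an aromatic carbon, meta to a large group, gives an at least 2.5-fold lower number from compound 1 to compound 3 (0.40 log units; beyond the scatter), which makes this the first readable step and shows that the read-out responds to a change at this position. Among these compounds, compound 3 gives the first exact value, whereas the earlier compounds showed only that the read-out could sit at the assay limit, and most of the series still sits there: the limit of > 64000 nM in this assay, at which 2 of the 3 values shown sit. The value of compound 1 is a limit and not a number, so the step is a bound and its full size stays unknown.

No other step can be read, as compound 2 differs from compound 3 in more than one place and its value is also a limit. The compounds shown leave open whether the shift follows the oxygen of the 3-methoxyphenoxy group or simply the larger group, and whether a hydroxyl, an ethoxy or an amine on the same aromatic carbon would move the number in the same direction.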